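Removing the Pyridine Methyl from a Nitro-Substituted Alkyne

The source may report more compounds than this note shows. Statements on the series, on what has been measured and on what is new or still open speak of the compounds shown alone.

Compound 1 `Cc1cccc(C#Cc2cc(C#N)cc([N+](=O)[O-])c2)n1` stands at the top of the three measured numbers in a functional assay on HEK293 cells for antagonist activity at metabotropic glutamate receptor 5 (Rattus norvegicus), read by calcium flux (on this read-out higher numbers stand for weaker inhibition and lower numbers for stronger inhibition), giving 3.68 nM. Its two neighbours differ only at the nitro group: compound 2 `Cc1cccc(C#Cc2cc(Cl)cc(C#N)c2)n1` gives 1.22 nM and compound 3 `Cc1cccc(C#Cc2cc(I)cc(C#N)c2)n1` gives 0.71 nM. The step of a 3.0-fold lower number from compound 1 to compound 2 (0.48 log units; beyond the scatter) and the step of a 5.2-fold lower number from compound 1 to compound 3 (0.71 log units; beyond the scatter) both lie beyond the scatter, while a 1.7-fold lower number from compound 2 to compound 3 (0.24 log units; within the scatter) lies within it.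

Compound 4 `N#Cc1cc(C#Cc2ccccn2)cc([N+](=O)[O-])c1` is compound 1 with a different change: hydrogen in place of methyl on an aromatic carbon, the change sitting on an aromatic carbon of a six-membered aromatic ring with 1 nitrogen, next to the ring nitrogen. None of the three measured steps touches this ring; all three concern the nitro group on the other ring, so they offer no direct guide. With nothing measured on this position, a small loss is expected rather than a gain, and the step of a 2.2-fold higher number from compound 1 to compound 4 (0.34 log units; beyond the scatter) is estimated to be modest. Compound 4 is therefore expected to give about 8 nM in this assay, with a range from 2 nM to 30 nM.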

Compound 4, half-maximal inhibitory concentration: 1.32 nM
Compound 4: the middle estimate sits 6.1-fold (0.78 log units) above what was measured, and the stated range ends above it.
By their numbers in this assay, from the lowest: compounds 3, 2 and 4 (each within the scatter of the next); then compound 1.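

In this assay, hydrogen in place of methyl on an aromatic carbon next to the ring nitrogen gives a 2.8-fold lower number from compound 1 to compound 4 (0.45 log units; beyond the scatter), a modest step beyond the scatter. Among the compounds shown here, this is the first reading at this position, since the earlier steps all concerned the nitro group and its replacements, and it shows that with the nitro group in place the methyl is not required for a low number: the number falls when it leaves. Nothing available here accounts for why the number moves in this direction.

On these data alone, whether the same change would shift the number in the same way in compound 2 or compound 3 remains open. So does the outcome of placing a larger group on this aromatic carbon, such as an ethyl, a methoxy or an amine.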